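This account rests on a few compounds, and the source may have more. Where it says the series, first, only, none or still open, it means among the compounds named here.

Measured compounds:
compound 1, `CNCc1cc(-c2cccnc2Cl)n(S(=O)(=O)c2cccnc2)c1`, -0.5
compound 2, `CNCc1cc(-c2cccnc2C)n(S(=O)(=O)c2cccnc2)c1`, 0.06
compound 3, `CNCc1cn(S(=O)(=O)c2cccnc2)c(-c2cccnc2F)c1C`, -0.4

In a physicochemical assay for lipophilicity, read by HPLC, at pH 7.4 (a higher number here means a more lipophilic compound, a lower number a more polar compound), compound 2 gives 0.06 and compound 1 gives -0.5. Among the measured compounds shown here, the one change between them is chloro in place of methyl on an aromatic carbon, and the step it made is a number 0.56 log units lower from compound 2 to compound 1 (beyond the scatter). Compound 3, with -0.4 in this assay, sits within the scatter of compound 1; against compound 2 its value is beyond the scatter. How the core of compound 3 differs from the core of compound 2 is not broken down here.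

Compound 4, `CNCc1cn(S(=O)(=O)c2cccnc2)c(-c2cccnc2F)c1Cl`, is not yet measured in this assay. It differs from compound 3 by chloro in place of methyl on an aromatic carbon. For the measured compounds named here, this is the same kind of change as the one from compound 2 to compound 1, but not the same: there the chloro entered on a six-membered aromatic ring with one nitrogen, next to the ring nitrogen and ortho to a large group, whereas here it enters on a five-membered aromatic ring with one nitrogen, next to the ring atom bearing the (methylamino)methyl group and next to the ring atom bearing the 2-fluoropyridin-3-yl group. Going by the values given here, only the one earlier occurrence of this change is measured, so the expectation rests on it alone. Among the compounds with values here, compound 4 is expected to move from compound 3 by a number 0.45 log units lower from compound 3 to compound 4 (beyond the scatter), a step of about the size seen from compound 2 to compound 1, because a number 0.56 log units lower from compound 2 to compound 1 (beyond the scatter) is the only such step available, with a wide allowance for the changed surroundings. Compound 4 is thus estimated at -0.85, between -1.4 and -0.3.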

Compound 4, distribution coefficient: 0.48
For compound 4 the middle estimate is 1.33 log units below the measured one; measured number outside the range, above it.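

In this assay, chloro in place of methyl on an aromatic carbon of a five-membered aromatic ring with 1 nitrogen gives a number 0.88 log units higher from compound 3 to compound 4 (beyond the scatter), while the same kind of change on the core of compound 2 gives a number 0.56 log units lower from compound 2 to compound 1 (beyond the scatter). Each step is beyond the scatter and they run in opposite directions, so in this series neither the direction nor the size of the step measured on one core can be carried to the other. With only these two occurrences, the data do not show which difference between the two settings goes with the reversal, and nothing measured here bears on the reason for it.

The compounds shown leave open how a bromo, a nitrile or a trifluoromethyl group on the same aromatic carbon as the chloro of compound 4 would read in this assay, and so whether compound 4 reflects something particular to chloro. Also open, as far as these compounds go, is whether the step from methyl to chloro keeps its direction when a dimethylaminomethyl group stands in place of the (methylamino)methyl group, or a phenyl group in place of the 2-fluoropyridin-3-yl group.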